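This account rests on a few compounds, and the source may have more. Where it says the series, first, only, none or still open, it means among the compounds named here.

Compound 1, `CN1CC2C=C(c3cnccc3Cl)CC(C2)C1`, gives 1160 nM in an in vitro assay on SH-EP1 cells for displacement of a labelled ligand from Neuronal acetylcholine receptor; alpha4/beta2 (Homo sapiens); on this read-out higher numbers stand for weaker inhibition and lower numbers for stronger inhibition.
Compound 2, `C1=C(c2cncc(OCc3ccccc3)c2)CC2CNCC1C2`, gives 0.7 nM in this assay.
Compound 3, `Clc1ccc(C2=CC3CNCC(C2)C3)nn1`, gives 0.4 nM in this assay.

Among these three numbers, compound 2 stands second highest. Its nearest neighbour is compound 3, whose number lies within the usual scatter of repeated measurements, so the two cannot be told apart; its furthest neighbour is compound 1, whose number is far higher and well beyond the scatter.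

Compound 4, `Clc1cccc(Oc2cncc(C3=CC4CNCC(C3)C4)c2)c1`, differs from compound 2 by 3-chlorophenyl in place of benzyl on an oxygen on an aromatic ring. Among the compounds with values here, no pair of measured compounds isolates this change, so the expectation rests on the whole set, and the step is estimated as small, leaning towards a somewhat higher number or none beyond the scatter, a 2.1-fold higher number from compound 2 to compound 4 (0.33 log units; beyond the scatter). Compound 4 is therefore expected to give about 1.5 nM in this assay, with a likely range from 0.4 nM to 6 nM.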

Compound 4, inhibition constant: 1 nM
Compound 4: middle estimate off by 1.5-fold (0.18 log units), on the high side; the measured number falls inside the stated range.
By their numbers in this assay, from the lowest: compounds 3, 2 and 4 (each within the scatter of the next, the first and the last beyond it); then compound 1.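

Between benzyl and 3-chlorophenyl on the oxygen, the read-out shows a 1.4-fold higher number from compound 2 to compound 4 (0.15 log units; within the scatter) in this assay, so the two groups cannot be told apart here. This position therefore takes either of these groups, which have the same heavy-atom count and one carbon-only aromatic ring each, and the number stays close to that of compound 2.

On these data alone, whether plain phenyl, methyl or a longer chain such as phenylethyl on this oxygen would read the same remains open. Nothing available explains why these two groups read alike.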